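The source may hold more compounds than are shown below. What is called first, only, known or untested is meant among the compounds shown, and "the series" means these compounds.

In a functional assay on Jurkat cells (Homo sapiens) for inhibition (a lower number here means a stronger inhibitor, a higher number a weaker inhibitor), compound 1 `CCOC(=O)c1cnc(N(C)N2C(=O)C=C(C)C2=O)nc1C(F)(F)C(F)(F)F` gives 350 nM; 450 nM (2 entries), as recorded in the several entries of compound 1 in this assay, 350 nM; 450 nM (2 entries). Compound 2 `CCOC(=O)c1cnc(N(C)N2C(=O)C=C(C)C2=O)nc1-c1ccsc1` gives 120 nM in this assay; this is the only number shown for compound 2, beside one further entry that carries no single number. Within the data shown here, the two structures differ in one place, but no step between them is worked out here, so only the two values themselves can be set side by side, and they are not read as a measured step. Compound 3 `CCOC(=O)c1cnc(N(C)N2C(=O)C=C(C)C2=O)nc1-c1ccc(C)s1` has not yet been measured. It differs from compound 2 by 5-methylthiophen-2-yl in place of thiophen-3-yl on an aromatic carbon. Among the measured compounds shown here, no measured step of this kind is available, so the expectation rests on compound 2 alone, whose value of 120 nM is the starting point. The change is expected to stay within the usual scatter, with no change at the digits printed from compound 2 to compound 3 (within the scatter) pointing neither clearly up nor clearly down. Compound 3 is therefore estimated at 120 nM in this assay, within a range from 40 nM to 360 nM.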

Compound 3, half-maximal inhibitory concentration: 350 nM
Compound 3: the middle estimate sits 2.9-fold (0.46 log units) below what was measured; the range from low to high includes it.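

In this assay, replacing thiophen-3-yl with 5-methylthiophen-2-yl on the aromatic carbon ortho to an ethoxycarbonyl group gives a 2.9-fold higher number from compound 2 to compound 3 (0.46 log units; beyond the scatter). Among these compounds, this position therefore distinguishes between two groups that share the same ring type and the same counts of hydrogen-bond donors and acceptors, something the separate values of the earlier compounds could not show as a measured step. Nor does a thiophene ring alone preserve the number seen for compound 2, as compound 3 gives 350 nM, a value that also stands among the repeat entries of compound 1: the several entries of compound 1 in this assay, 350 nM; 450 nM (2 entries).

The step combines two differences, the added methyl group and the different point of attachment of the thiophene ring, and the compounds shown do not separate them; an unsubstituted thiophen-2-yl or a methyl-bearing thiophen-3-yl group would be needed to do so. The compounds shown also leave open how this position responds to groups outside the thiophene series and the perfluorinated chain of compound 1, such as a phenyl ring, an amine or a carboxylic acid.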